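A Methyl on the Amine Nitrogen, Moved to a Second Core

The source may hold more compounds than are shown below. What is called first, only, known or untested is meant among the compounds shown, and "the series" means these compounds.

Measured so far:
compound 1, `CNCC(=O)Nc1cc(OC)ccc1C(=O)c1cc(OC)c(OC)c(OC)c1`: 690 nM
compound 2, `COc1ccc(C(=O)c2cc(OC)c(OC)c(OC)c2)c(NC(=O)CN(C)C)c1`: 470 nM
compound 3, `C=C(c1ccc2c(c1)C=CC(C)(C)O2)c1ccc(OC)cc1NC(=O)CN`: 160 nM

In a functional assay on HeLa cells (Homo sapiens) for antiproliferative activity, read by MTT assay, with a stated time of 48 h (on this read-out higher numbers stand for weaker inhibition and lower numbers for stronger inhibition), compound 1 gives 690 nM and compound 2 gives 470 nM. The change between them, (methyl in place of hydrogen on an amine nitrogen), made a 1.5-fold lower number from compound 1 to compound 2 (0.17 log units; within the scatter). Compound 3 gives 160 nM in this assay; how its core differs from that of compound 1 is not broken down here. Compound 4 `C=C(c1ccc2c(c1)C=CC(C)(C)O2)c1ccc(OC)cc1NC(=O)CNC` has not been measured; it carries methyl in place of hydrogen on an amine nitrogen. This is the same kind of change as the earlier one, not the same: in compound 1 the amine nitrogen has saturated chain carbon, saturated chain carbon as its other neighbours, whereas in compound 3 it has only saturated chain carbon. Compound 4 is expected to show a step of a 1.2-fold lower number from compound 3 to compound 4 (0.09 log units; within the scatter), because the earlier change of this kind gave a 1.5-fold lower number from compound 1 to compound 2 (0.17 log units; within the scatter). Compound 4 is estimated at 130 nM, between 60 nM and 300 nM.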

Compound 4, half-maximal inhibitory concentration: 410 nM
The estimate for compound 4 lay 3.2-fold (0.50 log units) below the measured number; measured number outside the range, above it.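

In this assay, methyl in place of hydrogen on the amine nitrogen gave a 2.6-fold higher number from compound 3 to compound 4 (0.41 log units; beyond the scatter), so on this core the change weakened inhibition. Set beside the earlier step, the same change did not carry over from one core to the other: the same change on two cores in this assay, a 1.5-fold lower number (0.17 log units; within the scatter) from compound 1 to compound 2 and a 2.6-fold higher number (0.41 log units; beyond the scatter) from compound 3 to compound 4, 3.8-fold (0.58 log units) apart, beyond the scatter of two such steps. This shows that, for these two pairs, the step on the core of compound 1 did not foretell the step on the core of compound 3; it does not show why the two differ, and one pair per core gives no rule for any other core.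

The compounds shown leave open how an ethyl group or a longer chain on this amine nitrogen would read on either core. They also leave open whether a second methyl, as in compound 2, would move the number on the core of compound 3.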